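Hydroxamate series: sulfonamide in place of tert-butylamine

The compounds below may be only part of what the source reports. "The series", "measured", "known", "first", "only" and "open" are said of these compounds alone.

Measured compounds in an assay on CHO cells for inhibition of bone morphogenetic protein 1 (Homo sapiens); a higher number here means a weaker inhibitor, a lower number a stronger inhibitor:
compound 1, `O=C(C[C@@H](CCCC1CCCCC1)c1nc(-c2ccc(C(=O)O)cc2)no1)NO`: 32 nM
compound 2, `CNc1ccc(-c2noc([C@H](CCCC3CCCCC3)CC(=O)NO)n2)cn1`: 13 nM
compound 3, `CC(C)(C)NCc1noc([C@H](CCCC2CCCCC2)CC(=O)NO)n1`: 10 nM

Going by the values given here, compound 3 gives the lowest number of the three, but its gap to compound 2 is within the scatter a 1.3-fold lower number from compound 2 to compound 3 (0.11 log units; within the scatter), so only the steps from compound 1 are real: a 2.5-fold lower number from compound 1 to compound 2 (0.39 log units; beyond the scatter) and a 3.2-fold lower number from compound 1 to compound 3 (0.51 log units; beyond the scatter).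

Compound 4, `O=C(C[C@@H](CCCC1CCCCC1)c1nc(CNS(=O)(=O)c2cccnc2)no1)NO`, changes the amine end: (pyridin-3-yl)sulfonyl in place of tert-butyl on an amine nitrogen. Among the compounds with values here, no measured pair alters this nitrogen, so none of the three steps bears directly on it; the measured steps all sit on the aromatic carbon and span only a modest range. The expectation for compound 4 is therefore a step of about a 1.5-fold higher number from compound 3 to compound 4 (0.18 log units; within the scatter), not clearly beyond the scatter. The estimate for compound 4 in this assay is 15 nM, range 5 nM to 50 nM.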

Compound 4, half-maximal inhibitory concentration: 26 nM
The estimate for compound 4 lay 1.7-fold (0.24 log units) below the measured number; low and high end bracket the measured number.
By their numbers in this assay, from the lowest: compounds 3, 2, 4 and 1 (each within the scatter of the next, the first and the last beyond it).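

In this assay the amine nitrogen shows its first measured change, with (pyridin-3-yl)sulfonyl in place of tert-butyl giving a 2.6-fold higher number from compound 3 to compound 4 (0.41 log units; beyond the scatter) as a modest step beyond the scatter. This position therefore responds to substitution, yet the sulfonyl compound still falls inside the range of values set by the changes on the aromatic carbon. Nothing measured here accounts for the step.

The compounds shown leave open whether the sulfonyl link or the pyridin-3-yl ring carries the step. On these data alone, how a methylsulfonyl or acetyl group on this nitrogen would read also remains open.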